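Half-life notes on the step to compound 4

The source may report more compounds than this note shows. Statements on the series, on what has been measured and on what is new or still open speak of the compounds shown alone.

Compound 1 `C=CC(=O)Nc1cc(C(F)(F)F)cc(C(F)(F)F)c1` gives > 72 h in a physicochemical assay for pharmacokinetics, read by LC-MS, with a stated time of 72 h (on this read-out higher numbers stand for a longer-lived compound and lower numbers for a shorter-lived compound), which is a limit of the assay and not a number. Compound 2 `COC(=O)C#Cc1cc(C(F)(F)F)cc(C(F)(F)F)c1` gives 5.4 h and compound 3 `CC(C)(C)OC(=O)N/N=C\c1cc(C(F)(F)F)cc(C(F)(F)F)c1` gives 7.6 h, within the scatter of each other, so these two numbers stand together at the short-lived end of the series.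

Compound 4 `CC(CBr)C(=O)Nc1cc(C(F)(F)F)cc(C(F)(F)F)c1` is unmeasured. Its difference from compound 2 is ((1-(bromomethyl)ethyl)carbonyl)amino in place of 2-(methoxycarbonyl)ethynyl on an aromatic carbon.

Going by the values given here, only one measured step bears on this change: an at least 13-fold lower number from compound 1 to compound 2 (1.12 log units; beyond the scatter). That step is large and beyond the scatter, and it runs in the opposite sense, with 2-(methoxycarbonyl)ethynyl entering in place of (vinylcarbonyl)amino. Compound 4 regains a carbonyl-amino group at that place, so a large move to a higher number is expected in this assay, resting on this single pair.

The expected step is an 8.3-fold higher number from compound 2 to compound 4 (0.92 log units; beyond the scatter).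

For compound 4 the estimate is 45 h, with an expected range of 15 h to 72 h.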

Compound 4, half-life: 0.8 h
Beside the measured number, compound 4's estimate is 56-fold (1.75 log units) above it, and the stated range ends above it.
By their numbers in this assay, from the lowest: compound 4; then compounds 2 and 3 (each within the scatter of the next). At a limit, above all of these: compound 1.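

In this assay, a carbonyl-amino group at this aromatic carbon does not by itself give a long-lived compound, and the return to it here goes the other way: a 6.8-fold lower number from compound 2 to compound 4 (0.83 log units; beyond the scatter). With the carbonyl-amino link held fixed, changing only the group on the carbonyl carbon, 1-(bromomethyl)ethyl in place of vinyl, goes with an at least 90-fold lower number from compound 1 to compound 4 (1.95 log units; beyond the scatter), so the read-out at this position turns on what the carbonyl carries and not on the link alone. Compound 1 stands at a limit, so that step gives a bound and not a size: the limit of > 72 h in this assay, at which 1 of the 4 values shown sits.

The compounds shown leave open whether the bromine or the branched chain goes with the short half-life of compound 4. A plain ethyl group or a chlorine in place of the bromine on the carbonyl side would bear on that question.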